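Cyclohexyl for dichlorophenyl on the enone chain

The source may hold more compounds than are shown below. What is called first, only, known or untested is meant among the compounds shown, and "the series" means these compounds.

Compound 2 `COc1ccc(C(=O)/C(=C/c2ccc(Cl)cc2Cl)CC(C)OC(C)=O)cc1` gives only a limit in a functional assay on MCF7 cells (Homo sapiens) for inhibition, read by XTT assay, with a stated time of 48 h (a lower number here means a stronger inhibitor, a higher number a weaker inhibitor), reported as > 100000 nM. This value sits at the limit of > 100000 nM in this assay, at which 1 of the 2 values shown sits. Compound 1 `COc1ccc(C(=O)/C(=C/C2CCCCC2)COC(=O)c2ccccc2)cc1`, which carries a cyclohexyl on its own chain, gives 13700 nM in this assay. Compound 3 `COc1ccc(C(=O)/C(=C/C2CCCCC2)CC(C)OC(C)=O)cc1` is not yet measured; it differs from compound 2 by cyclohexyl in place of 2,4-dichlorophenyl on a double-bonded chain carbon bound to a double-bonded chain carbon. Among the compounds with values here, no measured pair isolates this single change, so its size is open; a step toward stronger inhibition is expected in this assay because compound 1 gives 13700 nM. For compound 3 the expected value in this assay is 40000 nM (range 10000 nM to 150000 nM). The step this estimate implies is an at least 2.5-fold lower number from compound 2 to compound 3 (0.39 log units; beyond the scatter).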

Compound 3, half-maximal inhibitory concentration: > 100000 nM
Compound 3: no number, only a limit; the forecaster's own chance of this, stated with the estimate: 35%; at least 2.5-fold (0.39 log units) between middle value and limit.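

The step for cyclohexyl in place of 2,4-dichlorophenyl on a double-bonded chain carbon bound to a double-bonded chain carbon cannot be read, because compound 2 and compound 3 both stand as limits: the limit of > 100000 nM in this assay, at which 2 of the 3 values shown sit.

Cyclohexyl alone therefore does not secure a measurable value in this assay. With cyclohexyl held constant, 1-acetoxyethyl in place of benzoyloxy on a saturated chain carbon bound to a double-bonded chain carbon gives an at least 7.2-fold higher number from compound 1 to compound 3 (0.86 log units; beyond the scatter).

Open, from the compounds shown here alone, is whether benzoyloxy paired with 2,4-dichlorophenyl gives a measurable value. Also open, going by these compounds, is how a carboxylic acid or an amine would read on that saturated chain carbon.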